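Aryl swaps on the hydrazone carbon: cytotoxicity notes

A few compounds are considered here, and "the series" means these few. Any claim that something is new, unique, unknown or untested is made for them only; others in the source may bear on it.

Three analogues sharing one core have been run in an ADME assay on WI-38 cells (Homo sapiens) for cytotoxicity, read by MTT assay, with a stated time of 72 h; on this read-out higher numbers stand for weaker inhibition and lower numbers for stronger inhibition. Compound 1 `COc1ccc(/C=N/NC(=O)Nc2ccc(Oc3ccnc(-c4nncn4CCN(C)C)c3)c(F)c2)c(OC)c1` gives 6630 nM in this assay. Compound 2 `CN(C)CCn1cnnc1-c1cc(Oc2ccc(NC(=O)N/N=C/c3ccc(O)c(Br)c3)cc2F)ccn1` gives 5560 nM in this assay. Compound 3 `CN(C)CCn1cnnc1-c1cc(Oc2ccc(NC(=O)N/N=C/c3ccccc3O[N+](=O)[O-])cc2F)ccn1` gives 6860 nM in this assay. The three differ only in the aryl group on the carbon with a double bond to nitrogen, and every step among them stays within the scatter: a 1.2-fold lower number from compound 1 to compound 2 (0.08 log units; within the scatter), a 1.0-fold higher number from compound 1 to compound 3 (0.01 log units; within the scatter) and a 1.2-fold higher number from compound 2 to compound 3 (0.09 log units; within the scatter). Compound 3 thus stands level with both of the others; nothing separates it from compound 1 or from compound 2 beyond the noise of this assay.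

Compound 4 `CN(C)CCn1cnnc1-c1cc(Oc2ccc(NC(=O)N/N=C/c3ccc(F)cc3F)cc2F)ccn1` has not yet been measured in this assay. Its change from compound 3 is 2,4-difluorophenyl in place of 2-(nitrooxy)phenyl on a carbon with a double bond to nitrogen. Going by the values given here, the steps that bear on it are the earlier swaps at the same carbon, a 1.0-fold higher number from compound 1 to compound 3 (0.01 log units; within the scatter) and a 1.2-fold higher number from compound 2 to compound 3 (0.09 log units; within the scatter), both within the scatter, although none of the measured rings carried fluorine. On this basis the step from compound 3 to compound 4 in this assay is expected to be a 1.1-fold lower number from compound 3 to compound 4 (0.02 log units; within the scatter), none beyond the scatter. The estimate for compound 4 in this assay is 6500 nM, with a range from 3000 nM to 14000 nM.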

Compound 4, half-maximal inhibitory concentration: 5030 nM
Estimate against measurement, compound 4: 1.3-fold (0.11 log units) above, and the stated range covers the measured number.
By their numbers in this assay, from the lowest: compounds 4, 2, 1 and 3 (each within the scatter of the next).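

Going by these compounds alone, the 2,4-difluorophenyl group is the first ring at this carbon to carry fluorine, and in this assay it leaves the series level: a 1.4-fold lower number from compound 3 to compound 4 (0.13 log units; within the scatter), a 1.1-fold lower number from compound 2 to compound 4 (0.04 log units; within the scatter) and a 1.3-fold lower number from compound 1 to compound 4 (0.12 log units; within the scatter) are all within the scatter. The change from 2-(nitrooxy)phenyl also removes every hydrogen-bond acceptor counted on the leaving group, since the entering group has none, yet the read-out does not separate the two compounds, so among the four compounds shown neither fluorine on the ring nor the loss of those acceptors at this position registers as a difference in this cytotoxicity read-out. No supporting measurement bears on why these aryl groups read alike.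

All four compounds keep a six-membered aromatic ring of carbon only on this carbon, so the compounds shown leave open whether a ring carrying an amine or a carboxylic acid, or a saturated cyclohexyl ring in place of the aromatic one, would move the number beyond the scatter. They also leave open whether the shared core, held constant throughout, sets the level seen here, as no change outside this carbon appears among them.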